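A few compounds are considered here, and "the series" means these few. Any claim that something is new, unique, unknown or untested is made for them only; others in the source may bear on it.

Measured in a functional assay on ACHN cells (Homo sapiens); a higher number here means a weaker inhibitor of growth, a lower number a stronger inhibitor of growth:
- Compound 1 `O=S(=O)(/C=C/c1ccc(Cl)cc1)Cc1ccc(Nc2ncnc3ccccc23)cc1`: > 100000 nM
- Compound 2 `O=S(=O)(/C=C/c1ccc(Cl)cc1Cl)Cc1ccc(Nc2ncnc3ccccc23)cc1`: 100 nM

Compound 1 gives > 100000 nM, which is a limit and not a number. Going by the values given here, compound 2, at 100 nM, thus holds the only true number so far. Compound 3 `O=S(=O)(/C=C/c1ccc(Cl)cc1Cl)Cc1ccc(Nc2ncnc3cc(Cl)ccc23)cc1` carries one change from compound 2 chloro in place of hydrogen on an aromatic carbon. Among the compounds with values here, the only measured step of this kind is large, an at least 1000-fold lower number from compound 1 to compound 2 (3.00 log units; beyond the scatter), but it starts from a limit and lies at a different place, so it is a weak guide. No step beyond the scatter is therefore expected in this assay. The expected change is a 1.5-fold higher number from compound 2 to compound 3 (0.18 log units; within the scatter). For compound 3 the estimate is 150 nM, with an expected range from 30 nM to 1000 nM.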

Compound 3, concentration for 50% growth inhibition: 8000 nM
Compound 3: middle estimate off by 53-fold (1.73 log units), on the low side; the measured number lies above the stated range.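

In this assay, chloro in place of hydrogen on an aromatic carbon is far from a neutral change at this position, meta to a fused ring and para to a fused ring: it gives an 80-fold higher number from compound 2 to compound 3 (1.90 log units; beyond the scatter). The same kind of change at a different place, in the step to compound 2, went the opposite way, so among these compounds its direction depends on where the chloro sits. Nothing shown here accounts for the size of this step. The compounds shown leave open whether the higher number belongs to chloro alone or would also follow from fluoro, methoxy or an amine at this position.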